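The compounds below may be only part of what the source reports. "The series", "measured", "known", "first", "only" and "open" are said of these compounds alone.

Measured compounds, with half-maximal inhibitory concentrations:
compound 1 `CCc1cccc(-n2cc(COc3cccc(NC(=O)Nc4ccc(Cl)c(C(F)(F)F)c4)c3)nn2)c1` gives 37900 nM
compound 2 `CCc1ccc(-n2cc(COc3cccc(NC(=O)Nc4ccc(Cl)c(C(F)(F)F)c4)c3)nn2)cc1` gives 1950 nM
compound 3 `O=C(Nc1cccc(OCc2cn(-c3ccccc3Cl)nn2)c1)Nc1ccc(Cl)c(C(F)(F)F)c1` gives 1960 nM

All three were read in a functional assay on HepG2 cells (Homo sapiens) for inhibition, read by MTT assay, with a stated time of 72 h; a higher number here means a weaker inhibitor, a lower number a stronger inhibitor. Compound 1 stands at the highest number of the three, so it is the weakest inhibitor of the set: the step to compound 2 is a 19-fold lower number from compound 1 to compound 2 (1.29 log units; beyond the scatter), and the step to compound 3 is a 19-fold lower number from compound 1 to compound 3 (1.29 log units; beyond the scatter). Between compound 2 and compound 3 the step is a 1.0-fold higher number from compound 2 to compound 3 (0.00 log units; within the scatter), so these two cannot be ordered.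

Compound 4 `O=C(Nc1cccc(OCc2cn(-c3ccc(C(F)(F)F)cc3)nn2)c1)Nc1ccc(Cl)c(C(F)(F)F)c1` is not yet measured. It differs from compound 1 in one place: 4-(trifluoromethyl)phenyl in place of 3-ethylphenyl on an aromatic nitrogen. For the measured compounds named here, the change that bears on it most directly is the one from compound 1 to compound 2, where the group on the aromatic nitrogen was moved to the 4-position of the phenyl ring, with a large drop in the number. The change to 2-chlorophenyl in compound 3 gave a drop of the same size. A 4-substituted phenyl on the aromatic nitrogen is therefore expected to lower the number by a similar amount, because the step of a 19-fold lower number from compound 1 to compound 2 (1.29 log units; beyond the scatter) was large. The expected step is a 17-fold lower number from compound 1 to compound 4 (1.24 log units; beyond the scatter). Compound 4 is estimated at 2200 nM in this assay, with a range from 700 nM to 7000 nM.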

Compound 4, half-maximal inhibitory concentration: 1800 nM
Beside the measured number, compound 4's estimate is 1.2-fold (0.09 log units) above it, within the range that was stated.
By their numbers in this assay, from the lowest: compounds 4, 2 and 3 (each within the scatter of the next); then compound 1.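

In this assay the 4-(trifluoromethyl)phenyl group on the aromatic nitrogen gives a 21-fold lower number from compound 1 to compound 4 (1.32 log units; beyond the scatter) and so matches the large step seen earlier, now with a group that carries no ethyl. The exchange of ethyl for trifluoromethyl on the aromatic carbon gives a 1.1-fold lower number from compound 2 to compound 4 (0.03 log units; within the scatter) and the exchange of 2-chlorophenyl for 4-(trifluoromethyl)phenyl gives a 1.1-fold lower number from compound 3 to compound 4 (0.04 log units; within the scatter), so compounds 2, 3 and 4 cannot be ordered and compound 1 alone stands apart at this position. No measured evidence on the cause of these numbers is at hand.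

With 3-ethylphenyl carried by compound 1 only, the data do not separate the place of the group on the phenyl ring from the ethyl itself. On these data alone, whether an amine or a carboxylic acid in place of the trifluoromethyl would keep the number of compound 4 remains open.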